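The source may hold more compounds than are shown below. What is called first, only, known or untested is meant among the compounds shown, and "the series" means these compounds.

Of the compounds shown here, three of a shared core have so far been tested in a functional assay on the whole organism (artery, strain albino) with Rattus norvegicus as the target, with a stated time of 900 min, at a dose of 10 mg/kg by the oral route; a higher number here means more inhibition at the dose given (going by the name of the read-out), a lower number less inhibition. Compound 1, `CC1=C(C(=O)Nc2ccc(Br)cc2)C(c2ccc(Cl)cc2Cl)N=C(SCc2ccccc2)N1`, gives 8.2% in this assay. Compound 2, `CC1=C(C(=O)Nc2ccc(Br)cc2)C(c2ccc(Cl)cc2Cl)N=C(SCc2cccc(Cl)c2)N1`, gives 7.2%, and compound 3, `COc1ccc(C2N=C(SCc3ccccc3)NC(C)=C2C(=O)Nc2ccc(Br)cc2)cc1`, gives 5.6%. The three numbers sit within the scatter of one another, so none of them can be set apart from the rest; compound 3 simply stands alongside compounds 1 and 2 at a low level of inhibition.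

Compound 4, `COc1ccc(C2N=C(SCc3cccc(Cl)c3)NC(C)=C2C(=O)Nc2ccc(Br)cc2)cc1`, has not yet been measured. It differs from compound 3 in one place: chloro in place of hydrogen on an aromatic carbon. Within the data shown here, one measured step bears directly on this change, since the same exchange of hydrogen for chloro on the benzyl ring separates compound 1 from compound 2, and that step was a number 1 percentage points lower from compound 1 to compound 2 (within the scatter). The other measured step, a number 2.6 percentage points lower from compound 1 to compound 3 (within the scatter), concerns a different part of the molecule and also stayed within the scatter.

On this basis the change is expected to make no difference beyond the scatter in this assay, and the step from compound 3 to compound 4 is estimated at a number 0.6 percentage points lower from compound 3 to compound 4 (within the scatter). Compound 4 is therefore expected to give about 5%, within a range of -5% to 15%.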

Compound 4, a percentage reported as inhibition, in the whole organism at one dose (the size of the read-out at that dose, not a potency): 22.6%
Beside the measured number, compound 4's estimate is 17.6 percentage points below it, outside the stated range (above it).
By their numbers in this assay, from the lowest: compounds 3, 2 and 1 (each within the scatter of the next); then compound 4.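

In this assay, chloro in place of hydrogen on the benzyl ring, a change that had looked silent, counts once the saturated ring carbon carries 4-methoxyphenyl, with a number 17 percentage points higher from compound 3 to compound 4 (beyond the scatter). The same exchange on the core of compound 1 stayed within the scatter, so what this chloro does depends on the group on that saturated ring carbon: the same change on two cores in this assay, a number 1 percentage points lower (within the scatter) from compound 1 to compound 2 and a number 17 percentage points higher (beyond the scatter) from compound 3 to compound 4, 18 percentage points apart, beyond the scatter of two such steps Read from the other side, 4-methoxyphenyl in place of 2,4-dichlorophenyl counts only where the 3-chlorobenzyl group is present, with a number 15.4 percentage points higher from compound 2 to compound 4 (beyond the scatter), and the two changes together give more than either gave alone: the same change on two cores in this assay, a number 2.6 percentage points lower (within the scatter) from compound 1 to compound 3 and a number 15.4 percentage points higher (beyond the scatter) from compound 2 to compound 4, 18 percentage points apart, beyond the scatter of two such steps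

As far as these compounds go, whether a fluoro, a methyl or a methoxy on that benzyl ring would act as chloro does here remains open, as does whether chloro elsewhere on that ring would do the same. The compounds shown also cannot tell whether this dependence belongs to 4-methoxyphenyl in particular or would also appear with another group on the saturated ring carbon, such as an unsubstituted phenyl or a 4-aminophenyl.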